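The source may hold more compounds than are shown below. What is called first, only, known or untested is meant among the compounds shown, and "the series" means these compounds.

Working notes on the series.

Compound 1 `COc1ccccc1S(=O)(=O)/C=C/c1cccnc1Cl` gives 849 nM in an assay on U2OS cells for activation of nuclear factor erythroid 2-related factor 2 (Homo sapiens), read by chemiluminescence, with a stated time of 6 h; a higher number here means that more compound is needed for the effect, a lower number that less compound is needed. Compound 2 `COc1ccccc1S(=O)(=O)/C=C/c1ccc(Cl)nc1Cl` gives 178 nM in this assay; the change from compound 1 is chloro in place of hydrogen on an aromatic carbon, and it produced a 4.8-fold lower number from compound 1 to compound 2 (0.68 log units; beyond the scatter). Compound 3 `COc1cccc(S(=O)(=O)/C=C/c2cccnc2)c1` gives 6290 nM in this assay, the highest number among the three measured compounds; the difference between the core of compound 3 and the core of compound 1 is not broken down here.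

Compound 4 `COc1cccc(S(=O)(=O)/C=C/c2cccnc2Cl)c1` is not yet measured. Relative to compound 3 the change is chloro in place of hydrogen on an aromatic carbon. For the measured compounds named here, this is the same kind of change as the one from compound 1 to compound 2, not the same: in compound 4 the chloro sits next to the ring nitrogen and ortho to a large group, whereas in compound 2 it sits next to the ring nitrogen, meta to a chloro group and para to a large group.

Beside the measured step from compound 1 to compound 2, the step expected for compound 4 is a 4.8-fold lower number from compound 3 to compound 4 (0.68 log units; beyond the scatter), resting on compound 3 at 6290 nM and on the size of a 4.8-fold lower number from compound 1 to compound 2 (0.68 log units; beyond the scatter). The estimate for compound 4 in this assay is 1300 nM, with a range from 450 nM to 4000 nM.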

Compound 4, half-maximal effective concentration: 348 nM
Estimate against measurement, compound 4: 3.7-fold (0.57 log units) above; measured number outside the range, below it.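

Chloro in place of hydrogen on an aromatic carbon lowers the number on both cores in this assay, and the new step is an 18-fold lower number from compound 3 to compound 4 (1.26 log units; beyond the scatter). The direction of the change carried over from one core to the other, but its size did not: the same change on two cores in this assay, a 4.8-fold lower number (0.68 log units; beyond the scatter) from compound 1 to compound 2 and an 18-fold lower number (1.26 log units; beyond the scatter) from compound 3 to compound 4, 3.8-fold (0.58 log units) apart, beyond the scatter of two such steps. For the compounds shown here, these two pairs do not show what sets the size of the step, since the new chloro in compound 2 and the one in compound 4 differ in their place on the ring as well as in their core, and compound 1 already carries a chloro group while compound 3 carries none, so the gap cannot be assigned to any one of these differences.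

The compounds shown leave open whether fluoro, bromo, methyl or an amine in the place of the chloro in compound 4 would lower the number to a similar degree. They also leave open whether the chloro step would keep its direction on a core in which the methoxy group is replaced by a carboxylic acid.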